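Ethoxy to ethylsulfanyl on the aryl ring

The source may hold more compounds than are shown below. What is called first, only, known or untested is meant among the compounds shown, and "the series" means these compounds.

Measured so far:
Compound 1, `CCOc1ccccc1C1=NC(c2ccccc2)CO1`: in a physicochemical assay for lipophilicity (a lower number here means a more polar compound, a higher number a more lipophilic compound), compound 1 gives 4.22.
Compound 2, `Cc1cccc(C2=NC(c3ccccc3)CO2)c1`: in this assay compound 2 gives 4.11.

The two values of compound 1 and compound 2 lie within the scatter of each other, so the numbers of compound 1 and compound 2 cannot be told apart. Compound 3, `CCSc1ccccc1C1=NC(c2ccccc2)CO1`, is not yet measured. It differs from compound 1 in one place: ethylsulfanyl in place of ethoxy on an aromatic carbon. Among the compounds with values here, no measured pair shows this change. A rise beyond the scatter is expected for the step from compound 1 to compound 3, about a number 0.58 log units higher from compound 1 to compound 3 (beyond the scatter). For compound 3 the estimate is 4.8, between 4.5 and 5.1.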

Compound 3, partition coefficient: 4.04
Compound 3: the middle estimate sits 0.76 log units above what was measured; the whole stated range lies above it.
By their numbers in this assay, from the lowest: compounds 3, 2 and 1 (each within the scatter of the next).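

In this assay, within the data shown here, the exchange of ethoxy for ethylsulfanyl on this aromatic carbon, ortho to a large group, gives a number 0.18 log units lower from compound 1 to compound 3 (within the scatter) and is the first reading of this change. At this position, in this single pair, sulfur in place of oxygen leaves two numbers that cannot be told apart. Nothing measured here accounts for this result. On these data alone, whether the same holds for a longer chain such as propoxy, or for an amine at this position, remains open.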